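A few compounds are considered here, and "the series" means these few. Any claim that something is new, unique, unknown or untested is made for them only; others in the source may bear on it.

Compound 3 `CCN1CCN(c2cc(C)c3cc(NC(=O)c4ccc(Cl)c(Cl)c4)ccc3n2)CC1` gives 1380 nM in a functional assay on MCF7 cells (Homo sapiens) for antiproliferative activity, read by MTT assay, with a stated time of 72 h (on this read-out lower numbers stand for stronger inhibition and higher numbers for weaker inhibition), the lowest of the three numbers recorded: compound 2 `CCN1CCN(c2cc(C)c3cc(NC(=O)c4ccc5ccccc5n4)ccc3n2)CC1` gives 7060 nM and compound 1 `CCN1CCN(c2cc(C)c3cc(NC(=O)c4ccccc4F)ccc3n2)CC1` gives 32600 nM. Compound 4 `CCN1CCN(c2cc(C)c3cc(NC(=O)c4ccc(C)cc4)ccc3n2)CC1` differs from compound 3 by 4-methylphenyl in place of 3,4-dichlorophenyl on a carbonyl carbon. Within the data shown here, no measured step exchanges these two groups, but the steps that change the group on the carbonyl carbon were a 24-fold lower number from compound 1 to compound 3 (1.37 log units; beyond the scatter) and a 5.1-fold lower number from compound 2 to compound 3 (0.71 log units; beyond the scatter), both beyond the scatter, so changes at this place have shifted the numbers considerably. Since compound 3 gives 1380 nM and sits lowest, the new group is expected to raise the number by a modest amount, a 3.6-fold higher number from compound 3 to compound 4 (0.56 log units; beyond the scatter). Compound 4 is therefore estimated at 5000 nM, within a range of 1500 nM to 20000 nM.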

Compound 4, half-maximal inhibitory concentration: 6740 nM
Beside the measured number, compound 4's estimate is 1.3-fold (0.13 log units) below it, within the range that was stated.
By their numbers in this assay, from the lowest: compound 3; then compounds 4 and 2 (each within the scatter of the next); then compound 1.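

In this assay, 4-methylphenyl in place of 3,4-dichlorophenyl on the carbonyl carbon gives a 4.9-fold higher number from compound 3 to compound 4 (0.69 log units; beyond the scatter), so the lowest number does not carry over to every substituted phenyl group. The 4-methylphenyl and quinolin-2-yl groups cannot be told apart, with a 1.0-fold lower number from compound 2 to compound 4 (0.02 log units; within the scatter), which is within the scatter, while 4-methylphenyl still improves on 2-fluorophenyl, with a 4.8-fold lower number from compound 1 to compound 4 (0.68 log units; beyond the scatter). No evidence is available to explain these differences. From the compounds shown here alone, whether an amine or a carboxylic acid on the phenyl ring would match 3,4-dichlorophenyl remains open.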